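This account rests on a few compounds, and the source may have more. Where it says the series, first, only, none or still open, it means among the compounds named here.

For the measured compounds named here, in a functional assay on A549 cells (Homo sapiens) for antiproliferative activity, read by MTT assay, with a stated time of 48 h (a higher number here means a weaker inhibitor of growth, a lower number a stronger inhibitor of growth), compound 1 `COC(=O)N1N=C(c2cccc(O)c2)CC1c1cc(OC)c(OC)c(OC)c1` gives 3170 nM, the only true number so far. Compound 2 `COc1cc(C2CC(c3cccc(O)c3)=NN2C(=O)OCc2ccccc2)cc(OC)c1OC` reads > 10000 nM, which is a limit of the assay. Going by the values given here, the one measured step, an at least 3.1-fold higher number from compound 1 to compound 2 (0.49 log units; beyond the scatter), lies beyond the scatter, but it concerns a different group and bears only weakly on what follows. Compound 3 `COC(=O)N1N=C(c2ccc(O)cc2)CC1c1cc(OC)c(OC)c(OC)c1` moves the hydroxyl instead: 4-hydroxyphenyl in place of 3-hydroxyphenyl on a carbon with a double bond to nitrogen. Among the compounds with values here, with no measured step at this place, the expected change is a 1.3-fold higher number from compound 1 to compound 3 (0.10 log units; within the scatter), no shift beyond the scatter. Compound 3 is estimated at 4000 nM, with an expected range from 1200 nM to 10000 nM.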

Compound 3, concentration for 50% growth inhibition: 8570 nM
Beside the measured number, compound 3's estimate is 2.1-fold (0.33 log units) below it; low and high end bracket the measured number.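

Compound 3 has the same atoms as compound 1, yet 4-hydroxyphenyl in place of 3-hydroxyphenyl gives a 2.7-fold higher number from compound 1 to compound 3 (0.43 log units; beyond the scatter) in this assay. On this carbon, then, the place of the hydroxyl on the phenyl ring alone is enough to weaken growth inhibition modestly, and 3-hydroxyphenyl is the better of these two groups. Nothing shown here explains this difference.

As far as these compounds go, it remains open whether the hydroxyl is needed at all. A 3-aminophenyl or 3-methoxyphenyl group on this carbon could help to answer that.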